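From trifluoromethyl to methoxy: an expected rise

The source may hold more compounds than are shown below. What is called first, only, known or untested is meant among the compounds shown, and "the series" means these compounds.

Measured in a physicochemical assay for solubility, in phosphate buffer, at pH 7.4; on this read-out lower numbers stand for lower solubility and higher numbers for higher solubility:
- Compound 1 `CCOC(=O)c1c(-c2ccccc2C)[nH]c2cc(OC)ccc2c1=O`: > 100000 nM, a limit of the assay and not a number
- Compound 2 `CCOC(=O)c1c(-c2cccc(C)c2)[nH]c2cc(OC)ccc2c1=O`: 48000 nM
- Compound 3 `CCOC(=O)c1c(-c2ccc(C(F)(F)F)cc2)[nH]c2cc(OC)ccc2c1=O`: 8000 nM

Of the two actual numbers, compound 3 gives the lower, 8000 nM, while compound 2 gives 48000 nM. Compound 4 `CCOC(=O)c1c(-c2ccc(OC)cc2)[nH]c2cc(OC)ccc2c1=O` carries methoxy in place of trifluoromethyl on an aromatic carbon, para to a large group (methoxy in place of trifluoromethyl on an aromatic carbon). Among the measured compounds shown here, the only measured step, an at least 2.0-fold lower number from compound 1 to compound 2 (0.31 log units; beyond the scatter), is a different change, so it bears only loosely, showing that one small edit can move the numbers beyond the scatter. Because compound 3 gives 8000 nM at the low end of the values, a rise is expected. The estimated change in this assay is a 3.1-fold higher number from compound 3 to compound 4 (0.49 log units; beyond the scatter). For compound 4 the estimated value is 25000 nM, with an expected range from 8000 nM to 80000 nM.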

Compound 4, solubility: 8000 nM
For compound 4 the middle estimate is 3.1-fold (0.49 log units) above the measured one, within the range that was stated.
By their numbers in this assay, from the lowest: compounds 3 and 4 (each within the scatter of the next); then compound 2. At a limit, above all of these: compound 1.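

In this assay, this aromatic carbon, para to a large group, takes methoxy in place of trifluoromethyl with no change at the digits printed from compound 3 to compound 4 (within the scatter), so two quite different groups here can give the same reading. The 4-methoxyphenyl in place of 3-methylphenyl gives a 6.0-fold lower number from compound 2 to compound 4 (0.78 log units; beyond the scatter), which shows that the aryl substitution pattern can matter more than this swap did. The 4-methoxyphenyl in place of 2-methylphenyl gives an at least 12-fold lower number from compound 1 to compound 4 (1.09 log units; beyond the scatter), a step that starts from a limit and not a number: the limit of > 100000 nM in this assay, at which 1 of the 4 values shown sits.

As far as these compounds go, whether an amine or a carboxylic acid on this aromatic carbon would give a different number stays open. So does how a plain methyl group on this same carbon would compare.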